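The source may hold more compounds than are shown below. What is called first, only, known or untested is meant among the compounds shown, and "the series" means these compounds.

The measured compounds: compound 1, `Cc1cc(C)c(S(=O)(=O)N2CCC(C3OCC(C)CO3)CC2)c(C)c1`, which in a functional assay on DLD-1 cells (Homo sapiens) for antiproliferative activity, read by CellTiter-Glo, with a stated time of 72 h (on this read-out higher numbers stand for weaker inhibition and lower numbers for stronger inhibition), reaches only the limit of > 5000 nM. Compound 2, `Cc1cc(C)c(S(=O)(=O)N2CCC(N3CCC(c4ccccc4)CC3)CC2)c(C)c1`, which in this assay gives 865 nM. Compound 3, `Cc1cc(C)c(S(=O)(=O)N2CCC(c3ccccc3)CC2)c(C)c1`, which in this assay reaches only the limit of > 5000 nM.

Compound 3 thus stands at the limit of > 5000 nM in this assay, at which 2 of the 3 values shown sit, without a number of its own. The change to compound 4, `Cc1cc(C)c(S(=O)(=O)N2CCC(N3CCCCC3)CC2)c(C)c1`, is piperidin-1-yl in place of phenyl on a saturated ring carbon. Within the data shown here, the only measured step touching compound 3, a step that the two limits leave unreadable from compound 1 to compound 3, runs between two limits, so no measured step gives a readable size for this change. Compound 2, which carries a phenyl on a piperidin-1-yl, gives a number where compound 3 gives none, and compound 4 carries the piperidin-1-yl alone. Compound 4 is therefore expected near 3000 nM, within 800 nM to 10000 nM. The expected step is an at least 1.6-fold lower number from compound 3 to compound 4 (0.22 log units; that floor lies within the scatter), with a fair chance that only a limit is reported again.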

Compound 4, half-maximal inhibitory concentration: 2200 nM
For compound 4 the middle estimate is 1.4-fold (0.13 log units) above the measured one; the measured number falls inside the stated range.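

In this assay, piperidin-1-yl in place of phenyl on the saturated ring carbon gives an at least 2.2-fold lower number from compound 3 to compound 4 (0.35 log units; beyond the scatter), and the same group in place of the group of compound 1 gives an at least 2.2-fold lower number from compound 1 to compound 4 (0.35 log units; beyond the scatter). Hydrogen in place of phenyl gives a 2.5-fold higher number from compound 2 to compound 4 (0.41 log units; beyond the scatter). Phenyl therefore adds a modest gain on the piperidin-1-yl, while the piperidin-1-yl alone already gives a readable number. From the compounds shown here alone, how a morpholine or an open-chain amine such as dimethylamino would fare on this carbon stays open. Two compounds still have no number of their own: the limit of > 5000 nM in this assay, at which 2 of the 4 values shown sit.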